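The source may report more compounds than this note shows. Statements on the series, on what has been measured and on what is new or still open speak of the compounds shown alone.

Compound 1 `Clc1ccc2c(NCc3ncc[nH]3)ccnc2c1` gives 2.82 in a physicochemical assay for lipophilicity, at pH 7.4; a higher number here means a more lipophilic compound, a lower number a more polar compound.
Compound 2 `Clc1ccc2c(NCc3ncc(CN4CCCC4)[nH]3)ccnc2c1` gives 4.78 in this assay.
Compound 3 `Clc1ccc2c(NCc3nc(-c4ccccc4)cs3)ccnc2c1` gives 5.2 in this assay.

Compound 2 differs from compound 1 by one change, ((pyrrolidin-1-yl)methyl in place of hydrogen on an aromatic carbon), and that change made a step of a number 1.96 log units higher from compound 1 to compound 2 (beyond the scatter). Compound 4 `Clc1ccc2c(NCc3nc(-c4ccccc4)c(CN4CCCC4)s3)ccnc2c1` is not yet measured; it carries the same kind of change on compound 3, ((pyrrolidin-1-yl)methyl in place of hydrogen on an aromatic carbon). The surroundings differ: in compound 2 the new group sits on a five-membered aromatic ring with 2 nitrogen, next to the ring nitrogen, whereas in compound 4 it sits on a five-membered aromatic ring with 1 nitrogen and 1 sulfur, next to the ring sulfur and next to the ring atom that bears a phenyl group. The difference between the two cores is not broken down here. Because compound 1 to compound 2 showed a number 1.96 log units higher from compound 1 to compound 2 (beyond the scatter), a step of comparable size, a number 1.70 log units higher from compound 3 to compound 4 (beyond the scatter), is expected here. Compound 4 is therefore estimated at 6.9 in this assay, within 6 to 7.6.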

Compound 4, partition coefficient: 6.78
For compound 4 the middle estimate is 0.12 log units above the measured one, within the range that was stated.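

In this assay the (pyrrolidin-1-yl)methyl group in place of hydrogen gave a number 1.58 log units higher from compound 3 to compound 4 (beyond the scatter) and on the other core gave a number 1.96 log units higher from compound 1 to compound 2 (beyond the scatter) so the change moved the number the same way, and by a large amount, on both cores. Going by these compounds alone, these are only two pairs, which shows agreement between these two cores and sets no rule for any other core. No measurement here explains why the number rises with this change on either core.

On these data alone, it remains open whether a morpholine or a dimethylamino group in place of the pyrrolidine would give a step of similar size. As far as these compounds go, how a carboxylic acid on that same aromatic carbon would move the number is also open.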